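The compounds below may be only part of what the source reports. "The series", "measured", "known", "first", "only" and "open" are said of these compounds alone.

In a functional assay on RKO cells (Homo sapiens) for cytotoxicity, read by resazurin assay, with a stated time of 72 h (on this read-out lower numbers stand for stronger inhibition and higher numbers for weaker inhibition), compound 3 `Cc1nc2ccccc2n1-c1csc(Nc2ccccc2)n1` gives 50000 nM. Compound 1 `COc1ccc(Nc2nc(-n3c(C)nc4ccccc43)cs2)cc1` differs from compound 3 by methoxy in place of hydrogen on an aromatic carbon. In this assay compound 1 gives 52500 nM, so the step of a 1.1-fold higher number from compound 3 to compound 1 (0.02 log units; within the scatter). Compound 2 `Cc1nccn1-c1csc(Nc2ccccc2)n1` is built on another core; how the core of compound 2 differs from the core of compound 3 is not broken down here. For compound 2 the read-out in this assay is only a limit of the assay, > 100000 nM. That value is the limit of > 100000 nM in this assay, at which 1 of the 3 values shown sits.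

Compound 4 `COc1cccc(Nc2nc(-n3ccnc3C)cs2)c1` has not yet been measured. It differs from compound 2 by methoxy in place of hydrogen on an aromatic carbon. Among the measured compounds shown here, this is the same kind of change as the one from compound 3 to compound 1, yet the place is not the same: in compound 1 the methoxy sits para to a large group, in compound 4 it sits meta to a large group. Resting on the step of a 1.1-fold higher number from compound 3 to compound 1 (0.02 log units; within the scatter), the step expected here is a step that the limit leaves unreadable from compound 2 to compound 4. Compound 4 is therefore estimated to show about 120000 nM, quite possibly again only a limit, within a range from 40000 nM to 350000 nM.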

Compound 4, half-maximal inhibitory concentration: > 100000 nM
Compound 4: a limit, no number; the forecaster's own chance of this, stated with the estimate: 65%; the middle value is on the limit's open side.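

Among the compounds shown here, compound 4 gives only a limit in this assay, and so does compound 2, so no step between these two compounds can be read: the limit of > 100000 nM in this assay, at which 2 of the 4 values shown sit.

The compounds shown leave open whether methoxy in place of hydrogen changes the read-out at all on the core of compound 2, and whether its place on the ring matters.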